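Adding Carbon to a Hydroxypiperidine Amide

This account rests on a few compounds, and the source may have more. Where it says the series, first, only, none or still open, it means among the compounds named here.

- Compound 1 `COc1cc(C(=O)N2CCC(O)CC2)cc2nc(NCc3cccc(Cl)c3)oc12` gives 21.7 mL/min/kg
- Compound 2 `COc1cc(C(=O)N2CC[C@@H](O)C(C)(C)C2)cc2nc(NCc3cccc(Cl)c3)oc12` gives 51.7 mL/min/kg
- Compound 3 `COc1cc(C(=O)N2CC[C@H](O)[C@@H](C)C2)cc2nc(NCc3cccc(Cl)c3)oc12` gives 36.7 mL/min/kg

In an ADME assay on cells (Hepatocyte, Rattus norvegicus, strain Wistar) for pharmacokinetics, read by LC-MS, with a stated time of 90 min, tested at 1 uM (a lower number here means slower removal, a higher number faster removal of the compound), compound 3 gives 36.7 mL/min/kg, which lies within the scatter of both other compounds. Compound 4 `COc1cc(C(=O)N2CC(C)C(O)CC2C2CC2)cc2nc(NCc3cccc(Cl)c3)oc12` carries 2-cyclopropyl-4-hydroxy-5-methylpiperidin-1-yl in place of 4-hydroxy-3-methylpiperidin-1-yl on a carbonyl carbon.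

For the measured compounds named here, no measured step adds a cyclopropyl group, so the nearest guides are the steps that add methyl groups to the ring: a 2.4-fold higher number from compound 1 to compound 2 (0.38 log units; beyond the scatter) and a 1.7-fold higher number from compound 1 to compound 3 (0.23 log units; within the scatter). Removing one methyl gives a 1.4-fold lower number from compound 2 to compound 3 (0.15 log units; within the scatter). On that basis, the expected change is a 1.3-fold higher number from compound 3 to compound 4 (0.11 log units; within the scatter), a small rise that may not clear the scatter. For compound 4, the estimated clearance is 47 mL/min/kg, with an expected range of 26 mL/min/kg to 80 mL/min/kg.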

Compound 4, clearance: 63.3 mL/min/kg
Compound 4: the middle estimate sits 1.3-fold (0.13 log units) below what was measured; the measured number falls inside the stated range.
By their numbers in this assay, from the lowest: compounds 1, 3, 2 and 4 (each within the scatter of the next, the first and the last beyond it).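

Compound 4 joins compound 2 in standing clearly apart from the unbranched ring in this assay: a 2.9-fold higher number from compound 1 to compound 4 (0.46 log units; beyond the scatter). Against the rings that already carry methyl groups, the added cyclopropyl gives no step that can be told from noise: a 1.7-fold higher number from compound 3 to compound 4 (0.24 log units; within the scatter), and a 1.2-fold higher number from compound 2 to compound 4 (0.09 log units; within the scatter). Nothing measured here bears on the reason for these steps. As far as these compounds go, whether an ethyl group or an amine in place of the cyclopropyl would read the same remains open. So does whether the cyclopropyl would matter on the ring of compound 1, without the methyl.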